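The source may report more compounds than this note shows. Statements on the series, on what has been measured and on what is new or still open speak of the compounds shown alone.

Of the compounds shown here, three have been measured so far in an assay on isolated protein for inhibition of aldehyde dehydrogenase 1A1 (Homo sapiens), read by spectrophotometry, tested at 10 uM; on this read-out higher numbers stand for more inhibition at the one concentration tested (going by the name of the read-out) and lower numbers for less inhibition. Compound 1 `Cc1cccc(Cn2c(CN3CCN(C(=O)c4ccc(C#N)cc4)CC3)nc3ccccc32)c1` gives 20.8%, compound 2 `Cc1cccc(Cn2c(CN3CCN(C(=O)c4ccc(Cl)cc4)CC3)nc3ccccc32)c1` gives 23.2%, and compound 3 `O=C(C1CC1)N1CCN(Cc2nc3ccccc3n2CC2CC2)CC1` gives 21.2%; all three lie within the usual scatter of one another, so none stands apart. Within the data shown here, the one single-point step, a number 2.4 percentage points higher from compound 1 to compound 2 (within the scatter), is itself within the scatter.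

Compound 4 `CCCC(=O)N1CCN(Cc2nc3ccccc3n2Cc2cccc(C)c2)CC1` is reached from compound 2 by the change (propyl in place of 4-chlorophenyl on a carbonyl carbon). Among the measured compounds shown here, no measured step matches this kind of change; the step from compound 1 to compound 2 only swaps one substituent on the aromatic ring, and compound 3 differs from compound 2 in more than one place. Without a bearing step, compound 4 is expected to sit close to compound 2, with a number 3.2 percentage points lower from compound 2 to compound 4 (within the scatter) expected within the scatter. The estimate for compound 4 in this assay is therefore 20%, ranging from 8% to 32%.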

Compound 4, a percentage reported as inhibition, at one concentration (the size of the read-out at that concentration, not a potency): 79.1%
Estimate against measurement, compound 4: 59.1 percentage points below; the measured number lies above the stated range.
By their numbers in this assay, from the lowest: compounds 1, 3 and 2 (each within the scatter of the next); then compound 4.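

Among these compounds, compound 4 shows that the group on this carbonyl carbon, whose other neighbour is an amide-type nitrogen in a ring, can move the read-out far more than the earlier compounds suggested. In this assay propyl in place of 4-chlorophenyl gives a number 55.9 percentage points higher from compound 2 to compound 4 (beyond the scatter) and propyl in place of 4-cyanophenyl gives a number 58.3 percentage points higher from compound 1 to compound 4 (beyond the scatter), so the effect appears with both aromatic groups. The data shown give no explanation for this rise.

Still open, going by these compounds, is how a longer chain or an unsubstituted phenyl would read at this place. On these data alone, it is also open whether propyl would give a similar number with a different group on the rest of the core.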